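The compounds below may be only part of what the source reports. "The series", "measured", "known", "first", "only" and "open" are said of these compounds alone.

Measured so far in an assay (Rattus norvegicus) for inhibition of Fatty-acid amide hydrolase 1 (Homo sapiens); on this read-out higher numbers stand for weaker inhibition and lower numbers for stronger inhibition:
compound 1, `O=C(O)c1ccc(-c2cnc(C(=O)CCCCCCc3ccccc3)o2)cc1`, gives 60 nM;
compound 2, `COc1ccc(-c2cnc(C(=O)CCCCCCc3ccccc3)o2)cc1`, gives 100 nM;
compound 3, `NS(=O)(=O)c1ccc(-c2cnc(C(=O)CCCCCCc3ccccc3)o2)cc1`, gives 10 nM.

Compound 3 gives the lowest number of the three; the nearest gap is a 6.0-fold lower number from compound 1 to compound 3 (0.78 log units; beyond the scatter) and the widest is a 10-fold lower number from compound 2 to compound 3 (1.00 log units; beyond the scatter). Compound 4, `O=C(CCCCCCc1ccccc1)c1ncc(-c2ccc(C(=O)C(F)(F)F)cc2)o1`, carries (trifluoromethyl)carbonyl in place of sulfamoyl on an aromatic carbon. Within the data shown here, the steps that bear on this change are the two that altered the same position, a 6.0-fold lower number from compound 1 to compound 3 (0.78 log units; beyond the scatter) and a 10-fold lower number from compound 2 to compound 3 (1.00 log units; beyond the scatter), both modest and both toward lower numbers on arriving at sulfamoyl, while the step of a 1.7-fold higher number from compound 1 to compound 2 (0.22 log units; within the scatter) between the two other groups stayed within the scatter. Among the measured compounds shown here, no measured step covers (trifluoromethyl)carbonyl itself; so far, leaving sulfamoyl has meant a modest rise in this assay, so a modest rise is expected here too. The expected step is a 4.0-fold higher number from compound 3 to compound 4 (0.60 log units; beyond the scatter). Compound 4 is therefore estimated at 40 nM, with a range from 10 nM to 150 nM.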

Compound 4, inhibition constant: 65 nM
The estimate for compound 4 lay 1.6-fold (0.21 log units) below the measured number, and the stated range covers the measured number.
By their numbers in this assay, from the lowest: compound 3; then compounds 1, 4 and 2 (each within the scatter of the next).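

Sulfamoyl now stands apart at this position: a 6.5-fold higher number from compound 3 to compound 4 (0.81 log units; beyond the scatter) is a third modest rise on leaving it, after those seen with carboxy and methoxy. (Trifluoromethyl)carbonyl does not separate from those two groups, with a 1.5-fold lower number from compound 2 to compound 4 (0.19 log units; within the scatter) from the methoxy side and a 1.1-fold higher number from compound 1 to compound 4 (0.03 log units; within the scatter) on trifluoromethyl replacing hydroxy at the carbonyl carbon, both within the scatter. Carboxy, methoxy and (trifluoromethyl)carbonyl therefore read alike here.

Going by these compounds, whether a nitrile or a sulfonamide bearing a methyl on nitrogen would keep the low number seen with sulfamoyl remains open. Nothing at hand says what sets sulfamoyl apart.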